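Swapping oxan-4-yl for (oxolan-3-yl)methyl on compound 1

The source may hold more compounds than are shown below. What is called first, only, known or untested is meant among the compounds shown, and "the series" means these compounds.

Measured values in a functional assay on NCI-H460 cells (Homo sapiens) for cytotoxicity, read by MTT assay, with a stated time of 96 h; a higher number here means a weaker inhibitor, a lower number a stronger inhibitor
Compound 1 `CNc1nc(C)c2cc(-c3cnc(OC)c(NS(=O)(=O)c4ccc(F)cc4F)c3)cc(OC3CCOCC3)c2n1` gives 59 nM
Compound 2 `CCNc1nc(C)c2cc(-c3cnc(OC)c(NS(=O)(=O)c4ccc(F)cc4F)c3)cc(OC3CCOCC3)c2n1` gives 240 nM
Compound 3 `COc1ncc(-c2cc(OC3CCOCC3)c3nc(NCC4CC4)nc(C)c3c2)cc1NS(=O)(=O)c1ccc(F)cc1F` gives 410 nM

Compound 1 holds the lowest number of the three, and its steps to both others lie beyond the scatter. Compound 4 `CNc1nc(C)c2cc(-c3cnc(OC)c(NS(=O)(=O)c4ccc(F)cc4F)c3)cc(OCC3CCOC3)c2n1` has (oxolan-3-yl)methyl in place of oxan-4-yl on an oxygen on an aromatic ring, a difference set out as (oxolan-3-yl)methyl in place of oxan-4-yl on an oxygen on an aromatic ring in full. Going by the values given here, none of the measured steps touches that oxygen substituent. All of them change the saturated chain on the nitrogen instead. They show a 4.1-fold higher number from compound 1 to compound 2 (0.61 log units; beyond the scatter) and a 6.9-fold higher number from compound 1 to compound 3 (0.84 log units; beyond the scatter) as modest moves, with a 1.7-fold higher number from compound 2 to compound 3 (0.23 log units; within the scatter) inside the scatter. These steps therefore indicate only how large one change in this small set can be, not its direction at the new place. Among the compounds with values here, with compound 1 at 59 nM as the lowest number so far, a modest upward step in this assay is expected, although a step within the scatter remains possible. The expected move is a 2.2-fold higher number from compound 1 to compound 4 (0.34 log units; beyond the scatter) on this reasoning. For compound 4 the estimated value is 130 nM with an expected range from 40 nM to 400 nM in this assay.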

Compound 4, half-maximal inhibitory concentration: 310 nM
Compound 4: middle estimate off by 2.4-fold (0.38 log units), on the low side, within the range that was stated.
By their numbers in this assay, from the lowest: compound 1; then compounds 2, 4 and 3 (each within the scatter of the next).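

In this assay, going by these compounds alone, the oxygen substituent proves to matter: (oxolan-3-yl)methyl in place of oxan-4-yl gives a 5.3-fold higher number from compound 1 to compound 4 (0.72 log units; beyond the scatter), the first step in this set at this place, as all the earlier steps changed the chain on the nitrogen. The two groups have the same atoms, yet a five-membered ring on a carbon link in place of a six-membered ring bound directly to the oxygen still moves the number beyond the scatter. No measurement bears on why this step occurs.

The step changes ring size and the link to the oxygen together, so the compounds shown cannot separate the two changes. Oxolan-3-yl or (oxan-4-yl)methyl on the same oxygen would each alter only one of them, and how a piperidin-4-yl group would read at this place also remains open.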